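Swapping the aryl ring of compound 1 for a pyridine

This account rests on a few compounds, and the source may have more. Where it says the series, first, only, none or still open, it means among the compounds named here.

Compound 1 `COc1cccc(-c2cc(C)c(N3CCN(c4ncccn4)CC3)nn2)c1` gives the lowest number of the three measured compounds in a functional assay on BV-2 cells (Mus musculus) for inhibition, read by ELISA, with a stated time of 16 h (a higher number here means a weaker inhibitor, a lower number a stronger inhibitor), at 2600 nM. Compound 2 `Cc1cc(-c2cccc(F)c2)nnc1N1CCN(c2ncccn2)CC1` gives 33500 nM in this assay, and compound 3 `Cc1cc(-c2ccc(C(F)(F)F)cc2)nnc1N1CCN(c2ncccn2)CC1` gives 37400 nM. Going by the values given here, the single measured step from compound 1, a 13-fold higher number from compound 1 to compound 2 (1.11 log units; beyond the scatter), shows that altering the substituent on that aryl ring can weaken inhibition sharply. Compound 4 `Cc1cc(-c2cccnc2)nnc1N1CCN(c2ncccn2)CC1` differs from compound 1 by pyridin-3-yl in place of 3-methoxyphenyl on an aromatic carbon. Among the compounds with values here, no measured step exchanges the carbon-only ring for a ring carrying a ring nitrogen, so the change cannot be read off directly, yet the one step recorded from compound 1 was large and unfavourable. Compound 4 is therefore expected to be weaker than compound 1, with an estimated 3.5-fold higher number from compound 1 to compound 4 (0.54 log units; beyond the scatter). The estimate for compound 4 is 9000 nM, in the expected range 2500 nM to 35000 nM.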

Compound 4, half-maximal inhibitory concentration: > 100000 nM
Compound 4: a limit, no number (the forecaster's own chance of this, stated with the estimate: 10%); middle value at least 11-fold (1.04 log units) away from the limit.
By their numbers in this assay, from the lowest: compound 1; then compounds 2 and 3 (each within the scatter of the next). At a limit, above all of these: compound 4.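

Compound 4 reads > 100000 nM in this assay, which is a limit of the assay and not a number. Pyridin-3-yl in place of 3-methoxyphenyl gives an at least 38-fold higher number from compound 1 to compound 4 (1.58 log units; beyond the scatter), and in place of 3-fluorophenyl it gives an at least 2.9-fold higher number from compound 2 to compound 4 (0.47 log units; beyond the scatter). The earlier compounds shown here carried only carbon rings at this position, so they could not show that a ring nitrogen here weakens inhibition relative to both of these rings. From the compounds shown here alone, whether a methoxy group on the pyridine ring would recover inhibition remains open, as does how an amine or a carboxylic acid on the carbon-only ring would read.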